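The source may hold more compounds than are shown below. What is called first, only, known or untested is meant among the compounds shown, and "the series" means these compounds.

Measured so far in the series:
Compound 1 `Cc1cccc(C(=O)OC2CCC(CN3CCN(c4cc(=O)c5cc(C(F)(F)F)cc([N+](=O)[O-])c5s4)CC3)CC2)c1`. In an ADME assay on Vero cells (Chlorocebus sabaeus) for cytotoxicity, read by MTT assay, with a stated time of 48 h (a higher number here means a weaker inhibitor, a lower number a stronger inhibitor), compound 1 gives > 64 ug/mL, which is a limit of the assay and not a number.
Compound 2 `CC(C)C(=O)OC1CCC(CN2CCN(c3cc(=O)c4cc(C(F)(F)F)cc([N+](=O)[O-])c4s3)CC2)CC1`. In this assay compound 2 gives > 64 ug/mL, again a limit rather than a number.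
Compound 3 `COc1ccccc1C(=O)OC1CCC(CN2CCN(c3cc(=O)c4cc(C(F)(F)F)cc([N+](=O)[O-])c4s3)CC2)CC1`. In this assay compound 3 gives > 64 ug/mL, also a limit.

Compound 3 thus stands exactly where every value shown so far sits: the limit of > 64 ug/mL in this assay, at which 3 of the 3 values shown sit. The three measured steps, a step that the two limits leave unreadable from compound 1 to compound 2, a step that the two limits leave unreadable from compound 1 to compound 3 and a step that the two limits leave unreadable from compound 2 to compound 3, each join two limits, so none of them can be read for size or for direction. The step to compound 4 `O=C(OC1CCC(CN2CCN(c3cc(=O)c4cc(C(F)(F)F)cc([N+](=O)[O-])c4s3)CC2)CC1)c1ccc(F)cc1` alters the group on the carbonyl carbon once more: 4-fluorophenyl in place of 2-methoxyphenyl on a carbonyl carbon. No measured step bears on this change in a readable way, and nothing among the shown values separates the three measured compounds from one another. The expectation for compound 4 is therefore a further limit rather than a readable step, that is a step that the limit leaves unreadable from compound 3 to compound 4 in this assay. The estimate for compound 4 is 90 ug/mL, between 50 ug/mL and 200 ug/mL.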

Compound 4, half-maximal inhibitory concentration: > 64 ug/mL
Compound 4 ended at the assay's limit (the forecaster's own chance of this, stated with the estimate: 85%); the middle value does not contradict the limit.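

Compound 4 ends at a limit, as do compound 1, compound 2 and compound 3, so none of the steps among them can be read for size or direction: the limit of > 64 ug/mL in this assay, at which 4 of the 4 values shown sit.

The compounds shown leave open whether the group on the carbonyl carbon affects the read-out in this assay at all.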